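Solubility of Three Measured Compounds and One Still Unmeasured

This account rests on a few compounds, and the source may have more. Where it says the series, first, only, none or still open, it means among the compounds named here.

Compound 1 `CCOC(=O)c1c(-c2cccc(F)c2)[nH]c2cc(OC)ccc2c1=O` gives in a physicochemical assay for solubility, in phosphate buffer, at pH 7.4 (a higher number here means a more soluble compound, a lower number a less soluble compound), only a limit, > 100000 nM.
Compound 2 `CCOC(=O)c1c(-c2ccccc2)[nH]c2cc(OC)ccc2c1=O` gives in this assay only a limit, > 100000 nM.
Compound 3 `CCOC(=O)c1c(-c2cccc(F)c2)[nH]c2cccc(OC)c2c1=O` gives in this assay only a limit, > 100000 nM.

Compounds 1 and 2 share one core and differ by hydrogen in place of fluoro on an aromatic carbon. The step between them, a step that the two limits leave unreadable from compound 1 to compound 2, cannot be sized, since each end is a limit rather than a number. Compound 3 has the same atoms as compound 1 joined differently; the difference between the two cores is not broken down here.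

Compound 4 `CCOC(=O)c1c(-c2ccccc2)[nH]c2cccc(OC)c2c1=O`, not yet measured, differs from compound 3 by hydrogen in place of fluoro on an aromatic carbon, the same change made from compound 1 to compound 2, at the same place on the ring. What is known so far is summed up in the limit of > 100000 nM in this assay, at which 3 of the 3 values shown sit. Because of the limit of > 100000 nM in this assay, at which 3 of the 3 values shown sit, the expectation for compound 4 is that it too will sit at the limit rather than give a number. Compound 4 is expected to give 130000 nM in this assay, within 60000 nM to 300000 nM. That would be an expected step that the limit leaves unreadable from compound 3 to compound 4.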

Compound 4, solubility: > 100000 nM
Compound 4 ended at the assay's limit; the forecaster's own chance of this, stated with the estimate: 85%; the middle value is on the limit's open side.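

For the compounds shown here, compound 3 and compound 4 each give only a limit in this assay, and no step between them can be read. The compounds shown leave open how far each lies past that limit, and whether going from 3-fluorophenyl to phenyl moves the read-out at all, since all that can be stated is this: the limit of > 100000 nM in this assay, at which 4 of the 4 values shown sit.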